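Aryl thiocarbamate series: nitro for trichloromethyl, acid dissociation

The source may hold more compounds than are shown below. What is called first, only, known or untested is meant among the compounds shown, and "the series" means these compounds.

Measured so far, in a physicochemical assay for acid dissociation:
compound 1, `CC(=O)Nc1ccc(OC(=S)Nc2ccc(Sc3ccc([N+](=O)[O-])cc3)cc2)cc1`, gives 8.99
compound 2, `CC(=O)Nc1ccc(OC(=S)Nc2ccc(Sc3ccc(C(Cl)(Cl)Cl)cc3)cc2)cc1`, gives 9.01
compound 3, `Oc1ccc(OC(=S)Nc2ccc(Nc3ccc(C(Cl)(Cl)Cl)cc3)cc2)cc1`, gives 9.23

Compound 4, `O=[N+]([O-])c1ccc(Nc2ccc(NC(=S)Oc3ccc(O)cc3)cc2)cc1`, is not yet measured in this assay.

The three measured values lie close together. Compound 3 gives the highest number of the three, but its gaps to compound 2 and to compound 1 are both within the usual scatter, so no order among them can be read from these data.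

One structural change recurs twice in the series. Between compound 2 and compound 1 it reads (nitro in place of trichloromethyl on an aromatic carbon), and in this assay it made a step of a number 0.02 log units lower from compound 2 to compound 1 (within the scatter). Between compound 3 and compound 4 the same change is made: nitro in place of trichloromethyl on an aromatic carbon. The two place lines agree word for word, so this is the same change on a different core. How the core of compound 3 differs from the core of compound 2 is not broken down here; only the values of the two compounds are known, and those lie within the scatter of each other.

On that basis compound 4 is expected to sit close to compound 3, with an estimated step of a number 0.02 log units lower from compound 3 to compound 4 (within the scatter), resting on the measured step of a number 0.02 log units lower from compound 2 to compound 1 (within the scatter) being within the scatter. In this assay compound 4 is therefore estimated at 9.21, with a likely range from 8.9 to 9.52.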

Compound 4, acid dissociation constant: 9.22
Compound 4: middle estimate off by 0.01 log units, on the low side, within the range that was stated.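

In this assay, nitro in place of trichloromethyl on an aromatic carbon now gives a step of a number 0.01 log units lower from compound 3 to compound 4 (within the scatter), and on the other core the same change gives a step of a number 0.02 log units lower from compound 2 to compound 1 (within the scatter), so on both cores the swap stays within the scatter. This shows only that, across these two pairs, the change has not produced a step that can be told from the scatter on either core; it does not show that a step of real size would carry from one core to the other, and two pairs set no rule for the series beyond these four compounds. Nothing available here bears on why the steps come out as they do.

The compounds shown hold only trichloromethyl and nitro in this place, para to a large group, so it stays open whether an amine, a carboxylic acid or a longer chain on that aromatic carbon would give a step beyond the scatter in this assay. From the compounds shown here alone, it also stays open whether the swap of nitro for trichloromethyl would stay as small on any further core.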